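Swapping an ethoxy for a nitro on a shared core

The source may hold more compounds than are shown below. What is called first, only, known or untested is meant among the compounds shown, and "the series" means these compounds.

Measured so far:
compound 1, `COc1cccc2c1c(O)c(C(=O)N(C)c1cccc(C(C)(C)C)c1)c(=O)n2C`: 60%
compound 2, `CCOc1cccc2c1c(O)c(C(=O)N(C)c1ccccc1)c(=O)n2C`: 40%

In a functional assay on the whole organism for inhibition, with Mus musculus as the target, at a dose of 1 mg/kg by the oral route (a higher number here means more inhibition at the dose given (going by the name of the read-out), a lower number less inhibition), compound 1 gives 60%, and in this assay compound 2 gives 40%, the lower of the two numbers, with the gap to compound 1 beyond the usual scatter. Compound 3, `CN(C(=O)c1c(O)c2c([N+](=O)[O-])cccc2n(C)c1=O)c1ccccc1`, has not yet been measured. It differs from compound 2 by nitro in place of ethoxy on an aromatic carbon. For the measured compounds named here, no measured pair shows such a swap, so the step from compound 2 to compound 3 in this assay is uncertain; a step within the scatter, in either direction, is expected. The estimate for compound 3 in this assay is 38%, within 12% to 62%, meaning an expected step of a number 2 percentage points lower from compound 2 to compound 3 (within the scatter).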

Compound 3, a percentage reported as inhibition, in the whole organism at one dose (the size of the read-out at that dose, not a potency): 96%
For compound 3 the middle estimate is 58 percentage points below the measured one, outside the stated range (above it).
By their numbers in this assay, from the lowest: compound 2; then compound 1; then compound 3.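

In this assay, nitro in place of ethoxy on an aromatic carbon gives a number 56 percentage points higher from compound 2 to compound 3 (beyond the scatter). This position is therefore far from indifferent to the group it carries, even though the group leaving and the group entering each count the same number of heavy atoms. From the compounds shown here alone, one swap at one place cannot show whether the gain belongs to nitro alone, so it remains open how an amine or a carboxylic acid on the same carbon would read out. Nothing measured here accounts for the size of this step.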